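A few compounds are considered here, and "the series" means these few. Any claim that something is new, unique, unknown or untested is made for them only; others in the source may bear on it.

Of the compounds shown here, two that share one core have been measured in a functional assay for antagonist activity at corticotropin-releasing factor receptor 1 (Rattus norvegicus); a higher number here means a weaker inhibitor, a lower number a stronger inhibitor. Compound 1 `CCCC(C)n1c(=O)c(C)nc2c(-c3ccc(Cl)cc3Cl)ccnc21` gives 62 nM. Compound 2 `CC[C@@H](C1CC1)n1c(=O)c(C)nc2c(-c3ccc(Cl)cc3Cl)ccnc21` gives 7.4 nM. For the measured compounds named here, the single change between them, 1-cyclopropylpropyl in place of 1-methylbutyl on an aromatic nitrogen, brings an 8.4-fold lower number from compound 1 to compound 2 (0.92 log units; beyond the scatter). Going by the values given here, compound 2 therefore stands at the lowest of the two numbers seen so far, with compound 1 as its only neighbour and a clear gap between them.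

Compound 3 `CC[C@@H](COC)n1c(=O)c(C)nc2c(-c3ccc(Cl)cc3Cl)ccnc21` has not yet been measured. It differs from compound 2 in one place: methoxymethyl in place of cyclopropyl on a saturated chain carbon bound to an aromatic nitrogen and a saturated chain carbon. Among the compounds with values here, no measured step exchanges a cyclopropyl for a methoxymethyl, so nothing seen so far bears directly on this change. Within the data shown here, the only measured step concerns a different exchange on the same aromatic nitrogen and was modest in size. Lacking a precedent, the expectation for compound 3 is a step not far from the scatter, leaning toward a higher number, a 2.7-fold higher number from compound 2 to compound 3 (0.43 log units; beyond the scatter). The estimate for compound 3 in this assay is 20 nM, within a range from 5 nM to 80 nM.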

Compound 3, half-maximal inhibitory concentration: 74 nM
The estimate for compound 3 lay 3.7-fold (0.57 log units) below the measured number, and the stated range covers the measured number.
By their numbers in this assay, from the lowest: compound 2; then compounds 1 and 3 (each within the scatter of the next).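

In this assay, cyclopropyl and methoxymethyl both hold 3 heavy atoms, yet exchanging the ring for the open chain with its oxygen brings a 10-fold higher number from compound 2 to compound 3 (1.00 log units; beyond the scatter), so this position responds strongly to what the group is, even when its heavy-atom count stays the same. Compared with 1-methylbutyl, 1-(methoxymethyl)propyl gives a 1.2-fold higher number from compound 1 to compound 3 (0.08 log units; within the scatter), which means these two open side chains cannot be told apart in this assay, and of the three compounds only compound 2, the one carrying the cyclopropyl ring, stands clear of the others. Nothing available beyond these numbers explains why the ring and the methoxymethyl group differ so much.

The compounds shown cannot separate the effect of losing the ring from the effect of adding the oxygen, since an open all-carbon group such as isopropyl on the same carbon would be needed to tell the two apart. They also leave open whether a larger ring such as cyclobutyl would keep the low number of compound 2, and whether a hydroxymethyl group would behave like methoxymethyl.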